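A few compounds are considered here, and "the series" means these few. Any claim that something is new, unique, unknown or untested is made for them only; others in the source may bear on it.

Measured so far in a functional assay on DU-145 cells (Homo sapiens) for inhibition, read by trypan blue exclusion, with a stated time of 96 h; a higher number here means a weaker inhibitor of growth, a lower number a stronger inhibitor of growth
- compound 1 `O=C(/C(=C\c1ccc(O)c([N+](=O)[O-])c1)SCc1ccc(Br)cc1)c1c(F)c(F)c(F)c(F)c1F` gives 10000 nM
- compound 2 `Cc1ccc(CS/C(=C/c2c(O)cc(O)cc2O)C(=O)c2ccc(Cl)cc2)cc1` gives 50000 nM
- compound 3 `O=C(O)c1ccc(C(=O)/C(=C\c2ccc(O)c([N+](=O)[O-])c2)SCc2ccc(Br)cc2)cc1` gives 50000 nM

Compound 3 at 50000 nM stands level with compound 2 , and these two share the highest number of the three. Compound 4 `O=C(/C(=C\c1ccc(O)c([N+](=O)[O-])c1)SCc1ccc(Br)cc1)c1ccc(Br)cc1` is the next to consider. It carries bromo in place of carboxy on an aromatic carbon, para to a large group (bromo in place of carboxy on an aromatic carbon), so 4-carboxyphenyl becomes 4-bromophenyl.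

Within the data shown here, only one measured step changes this same group: a 5.0-fold higher number from compound 1 to compound 3 (0.70 log units; beyond the scatter). Read in reverse, it shows that compound 1 , which has no carboxy, sits at 10000 nM. Compound 2 differs from compound 3 in several places and gives no clean guide. With a single modest step as evidence, a lower number of similar size is expected, though with wide uncertainty. The expected change is a 4.2-fold lower number from compound 3 to compound 4 (0.62 log units; beyond the scatter). For compound 4 the estimate is 12000 nM, with an expected range of 3000 nM to 50000 nM.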

Compound 4, concentration for 50% growth inhibition: 10000 nM
Beside the measured number, compound 4's estimate is 1.2-fold (0.08 log units) above it, within the range that was stated.
By their numbers in this assay, from the lowest: compounds 1 and 4 (each within the scatter of the next); then compounds 2 and 3 (each within the scatter of the next).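

Bromo in place of carboxy gives a 5.0-fold lower number from compound 3 to compound 4 (0.70 log units; beyond the scatter) in this assay, so compound 3 now stands apart from two carboxy-free partners rather than one. The aryl group itself matters less in this small set: 4-bromophenyl in place of 2,3,4,5,6-pentafluorophenyl gives no change at the digits printed from compound 1 to compound 4 (within the scatter), which leaves the two halogenated aryl groups indistinguishable here and places the only step beyond the scatter among these three on the presence of carboxy. Nothing measured here speaks to a cause for this step.

Open, going by these compounds, is whether the higher number is specific to carboxy, which a methyl ester, a primary amide or an amine at this aromatic carbon would test. Also open, on these data alone, is whether the same step appears when the rest of the shared core is changed.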